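The source may hold more compounds than are shown below. What is called first, only, known or untested is meant among the compounds shown, and "the series" means these compounds.

In a physicochemical assay for solubility, in phosphate buffer, measured as kinetic solubility, at pH 7.4 (a lower number here means a less soluble compound, a higher number a more soluble compound), compound 1 `Cc1oc(-c2c(Cl)cccc2C(F)(F)F)nc1CN1CCC(C(=O)NCCCN2C[C@H](C)C[C@H](C)C2)CC1` gives 65.1 ug/mL as its reading. Compound 2 `COc1cccc(Br)c1-c1nc(CN2CCC(C(=O)NCCCN3C[C@H](C)C[C@H](C)C3)CC2)c(C)o1` gives > 83 ug/mL as its reading, which is a limit of the assay and not an exact number. Compound 3 `COc1cccc(C)c1-c1nc(CN2CCC(C(=O)NCCCN3C[C@H](C)C[C@H](C)C3)CC2)c(C)o1` has not been measured yet. It differs from compound 2 in one place: methyl in place of bromo on an aromatic carbon describes methyl in place of bromo on an aromatic carbon, ortho to a large group. Among the compounds with values here, no measured step makes this exact exchange. The nearest evidence is an at least 1.2-fold higher number from compound 1 to compound 2 (0.10 log units; that floor lies within the scatter) for 2-bromo-6-methoxyphenyl in place of 2-chloro-6-(trifluoromethyl)phenyl, and this single guide stays within the scatter. On the strength of that step in compound 2, no change beyond the scatter is expected in this assay for this exchange. The expected step is an at least 1.0-fold lower number from compound 2 to compound 3 (0.01 log units; that floor lies within the scatter) by this estimate. For compound 3 the estimate is 80 ug/mL as a central value, with an expected range from 50 ug/mL to 120 ug/mL around it.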

Compound 3, solubility: > 73 ug/mL
Compound 3: a limit, no number; the forecaster's own chance of this, stated with the estimate: 45%; the middle value does not contradict the limit.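

In this assay compound 3 gives > 73 ug/mL, which is a limit of the assay and not a number, so the methyl analogue also reads as a limit, as the bromo analogue did. The step between compound 2 and compound 3 cannot be read, so this exchange of bromo for methyl has no measurable size here. Against the chloro and trifluoromethyl compound, the only readable step is an at least 1.1-fold higher number from compound 1 to compound 3 (0.04 log units; that floor lies within the scatter), and it shows no difference beyond the scatter.

As far as these compounds go, the true readings of compound 2 and compound 3 remain unknown, and so does any real difference between bromo and methyl on this aromatic carbon. From the compounds shown here alone, it also remains open whether a group of another kind at this place, such as an amine or a carboxylic acid, would shift the reading beyond the scatter.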